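This account rests on a few compounds, and the source may have more. Where it says the series, first, only, none or still open, it means among the compounds named here.

Measured so far in an ADME assay on MT4 cells (Homo sapiens) for cytotoxicity, read by MTT assay, with a stated time of 5 days; on this read-out higher numbers stand for lower toxicity in this test and lower numbers for higher toxicity in this test:
compound 1 `O=C(CSc1ncnn1-c1ccc(Cl)cc1Cl)Nc1ccccc1F` gives 38400 nM
compound 2 `O=C(CSc1ncnn1-c1ccc(Cl)cc1Cl)Nc1cccnc1Cl` gives 98500 nM
compound 3 `Cc1ccccc1NC(=O)CSc1ncnn1-c1ccc(Cl)cc1Cl` gives 106000 nM

Compound 3 shares the upper end of this small set with compound 2, the comparison being a 1.1-fold higher number from compound 2 to compound 3 (0.03 log units; within the scatter) here, and it stands clear of compound 1. Compound 4 `O=C(CSc1ncnn1-c1ccc(Cl)cc1Cl)Nc1ccc(Cl)cc1Br` carries 2-bromo-4-chlorophenyl in place of 2-methylphenyl on the amide-type nitrogen, and the change counts as 2-bromo-4-chlorophenyl in place of 2-methylphenyl on an amide-type nitrogen overall.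

The closest measured guide is a 2.8-fold higher number from compound 1 to compound 3 (0.44 log units; beyond the scatter) in which methyl replaces fluoro on an aromatic carbon. Read backwards, this modest step suggests that a halogen in place of methyl could lower the number. Compound 2 goes against this reading, since it holds a chloro group and still shows a 2.6-fold higher number from compound 1 to compound 2 (0.41 log units; beyond the scatter) as its step. Among the measured compounds shown here, no measured compound carries a bromo group.

A modest fall is therefore expected, with a 2.4-fold lower number from compound 3 to compound 4 (0.37 log units; beyond the scatter) as the estimated step. For compound 4 the estimated value is 45000 nM with an expected range from 15000 nM to 120000 nM on this read-out.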

Compound 4, half-maximal cytotoxic concentration: 189000 nM
The estimate for compound 4 lay 4.2-fold (0.62 log units) below the measured number; measured number above the stated range.
By their numbers in this assay, from the lowest: compound 1; then compounds 2, 3 and 4 (each within the scatter of the next).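

In this assay, 2-bromo-4-chlorophenyl on the amide-type nitrogen gives a 1.8-fold higher number from compound 3 to compound 4 (0.25 log units; within the scatter) and a 1.9-fold higher number from compound 2 to compound 4 (0.28 log units; within the scatter) so compound 4 cannot be told apart from compound 3 or compound 2, although the entering group brings both a bromine and a chlorine. Only the 2-fluorophenyl compound stands apart, with a 4.9-fold higher number from compound 1 to compound 4 (0.69 log units; beyond the scatter) so among these four compounds, a halogen on this ring does not by itself mark the low end, as compound 2 and compound 4 show. Nothing available here accounts for this result.

The aryl groups shown carry only halogen or methyl substituents, and compound 2 alone has a ring nitrogen. As far as these compounds go, it remains open how an amine or a carboxylic acid on this ring, or a longer chain in place of the ring on the amide-type nitrogen, would read in this assay.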